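Replacing the Aryl Group on a Shared Core

The compounds below may be only part of what the source reports. "The series", "measured", "known", "first", "only" and "open" are said of these compounds alone.

Measured so far:
Compound 1 `CC(C)OC(=O)N1CCC(Oc2ncnc3c2CCN3c2ccc(S(C)(=O)=O)cc2)CC1`: 154%
Compound 2 `CC(C)OC(=O)N1CCC(Oc2ncnc3c2CCN3c2ccc(C#N)c(F)c2)CC1`: 121%

Both compounds were tested in a functional assay on CHO-K1 cells with Glucose-dependent insulinotropic receptor (Homo sapiens) as the target, read by a luciferase reporter, with a stated time of 5 h; a higher number here means a larger maximal response, a lower number a smaller maximal response. Compound 1 `CC(C)OC(=O)N1CCC(Oc2ncnc3c2CCN3c2ccc(S(C)(=O)=O)cc2)CC1` gives 154%, and compound 2 `CC(C)OC(=O)N1CCC(Oc2ncnc3c2CCN3c2ccc(C#N)c(F)c2)CC1` gives 121%. Within the data shown here, compound 2 thus stands lowest of the two numbers; its nearest neighbour is compound 1, and the only step measured so far is a number 33 percentage points lower from compound 1 to compound 2 (beyond the scatter), a large drop beyond the scatter.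

Compound 3 `CC(C)OC(=O)N1CCC(Oc2ncnc3c2CCN3c2ccc([S+]([O-])N(C)C)cc2)CC1` differs from compound 2 in one place: a group of 11 heavy atoms (8 carbon, 1 nitrogen, 1 oxygen, 1 sulfur; one six-membered aromatic ring of carbon only) in place of a group of 9 heavy atoms (7 carbon, 1 nitrogen, 1 fluorine; one six-membered aromatic ring of carbon only), on a nitrogen on an aromatic ring in a ring. The group that leaves is exactly the one whose arrival accompanied the drop a number 33 percentage points lower from compound 1 to compound 2 (beyond the scatter), and the group that enters, like the group in compound 1, carries sulfur and oxygen. Among the measured compounds shown here, the single measured step therefore bears directly on this change and points to a rise in this assay, though not with certainty back to the level of compound 1. Compound 3 is expected to give about 145%, within a range from 115% to 175%. This estimate corresponds to the step of a number 24 percentage points higher from compound 2 to compound 3 (beyond the scatter).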

Compound 3, largest response reached (reported as percent of maximum), in percent of the reference or control that the assay uses: 128%
Beside the measured number, compound 3's estimate is 17 percentage points above it; the range from low to high includes it.
By their numbers in this assay, from the lowest: compounds 2 and 3 (each within the scatter of the next); then compound 1.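

In this assay, sulfur and oxygen in the group on the ring nitrogen are not enough to keep the response of the 4-(methylsulfonyl)phenyl compound. The change to compound 3 gives a number 7 percentage points higher from compound 2 to compound 3 (within the scatter), so compound 2 and compound 3 cannot be told apart here, even though their groups differ in makeup. The change made on the aromatic carbon, with the rest of the molecule kept, gives a number 26 percentage points lower from compound 1 to compound 3 (beyond the scatter), and nothing available here explains this difference.

On these data alone, it remains open whether the larger response belongs to the methylsulfonyl group alone or whether other groups in that place could match it. An amine or a carboxylic acid on the same aromatic carbon would help to separate these two possibilities.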